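An Ethyl Group Added to a Weakly Active Compound

A few compounds are considered here, and "the series" means these few. Any claim that something is new, unique, unknown or untested is made for them only; others in the source may bear on it.

Compound 1, `CC(=O)Nc1ccc(-n2nncc2CN2C(=O)C3(C(C#N)=C(N)Oc4c3c3nc5ccccc5nc3c3ccccc43)c3ccccc32)cc1`, gives > 50000 nM in a functional assay on HepG2 cells (Homo sapiens) for antiproliferative activity, read by MTT assay, with a stated time of 48 h; a lower number here means a stronger inhibitor, a higher number a weaker inhibitor.
Compound 2, `N#CC1=C(N)Oc2c(c3nc4ccccc4nc3c3ccccc23)C12C(=O)N(Cc1cnnn1-c1cccc(S(N)(=O)=O)c1)c1ccccc12`, gives 21500 nM in this assay.
Compound 3, `Cc1ccccc1-n1nncc1CN1C(=O)C2(C(C#N)=C(N)Oc3c(N)cc4nc5ccccc5nc4c32)c2ccccc21`, gives > 50000 nM in this assay.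

The values for compound 1 and compound 3 are limits of this assay and not numbers. Among the measured compounds shown here, compound 2 is the only one of the three with a measured number, and the step of an at least 2.3-fold lower number from compound 1 to compound 2 (0.36 log units; beyond the scatter) is the only measured step. That step concerns 3-sulfamoylphenyl in place of 4-acetamidophenyl on an aromatic nitrogen, a change of a different kind from the one that follows.

Compound 4, `CCc1cccc(C)c1-n1nncc1CN1C(=O)C2(C(C#N)=C(N)Oc3c(N)cc4nc5ccccc5nc4c32)c2ccccc21`, differs from compound 3 in one place: ethyl in place of hydrogen on an aromatic carbon. For the measured compounds named here, no measured step shows what an ethyl group added to an aromatic carbon does. Compound 3 stands at the limit of this assay, as does compound 1 (the limit of > 50000 nM in this assay, at which 2 of the 3 values shown sit), so the starting point is already at the edge of what the assay reports. Going by the values given here, with no step to lean on, the expectation for compound 4 is no step beyond the scatter, a number no higher from compound 3 to compound 4 (the limit leaves the size open), and compound 4 is therefore estimated at 50000 nM, with a range from 20000 nM to 150000 nM, most likely reported again only as a limit.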

Compound 4, half-maximal inhibitory concentration: > 50000 nM
Compound 4: no number, only a limit; the forecaster's own chance of this, stated with the estimate: 70%; the middle value lies on the limit itself.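

In this assay compound 4 gives > 50000 nM, a limit and not a number. Among the compounds shown here, compound 3 also stands at a limit, so no step between compound 3 and compound 4 can be read. The compounds shown leave open what ethyl in place of hydrogen on an aromatic carbon does in this series, and the limit remains the most common result: the limit of > 50000 nM in this assay, at which 3 of the 4 values shown sit.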